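Fluoro on the aryl ring of the isopropyl carbamate

The source may hold more compounds than are shown below. What is called first, only, known or untested is meant among the compounds shown, and "the series" means these compounds.

Compound 1 `CC(C)OC(=O)N1CCC(Oc2ncnc3c2CCN3c2ccc(S(C)(=O)=O)cc2)CC1` gives 154% in a functional assay on CHO-K1 cells with Glucose-dependent insulinotropic receptor (Homo sapiens) as the target, read by a luciferase reporter, with a stated time of 5 h (a higher number here means a larger maximal response, a lower number a smaller maximal response), the highest of the three numbers in hand. Compound 2 `CS(=O)(=O)c1ccc(N2CCc3c(OC4CCN(C(=O)OCCF)CC4)ncnc32)c(F)c1` gives 86% and compound 3 `COCCOC(=O)N1CCC(Oc2ncnc3c2CCN3c2ccc(S(C)(=O)=O)cc2F)CC1` gives 86%; both lie beyond the scatter below compound 1, and their two values do not differ from each other beyond the scatter. Among the compounds with values here, the only single-change step measured so far, no change at the digits printed from compound 2 to compound 3 (within the scatter), concerns the carbamate chain and says nothing about the aryl ring.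

Compound 4 `CC(C)OC(=O)N1CCC(Oc2ncnc3c2CCN3c2ccc(S(C)(=O)=O)c(F)c2)CC1` differs from compound 1 by fluoro in place of hydrogen on an aromatic carbon, which, taken one bond further out, reads 4-(methylsulfonyl)phenyl to 3-fluoro-4-(methylsulfonyl)phenyl. Within the data shown here, no measured step isolates a fluoro on this ring: compounds 2 and 3 carry a fluoro on the ring together with a different carbamate, so their lower values cannot be attributed to the ring substitution alone. The expectation therefore rests on the fact that every fluoro-bearing analogue measured gives a smaller maximal response than compound 1, while the carbamate of compound 1 is retained in compound 4. A moderate downward step, a number 34 percentage points lower from compound 1 to compound 4 (beyond the scatter), is estimated. For compound 4 the estimate in this assay is 120%, with a range from 80% to 160%.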

Compound 4, largest response reached (reported as percent of maximum), in percent of the reference or control that the assay uses: 109%
For compound 4 the middle estimate is 11 percentage points above the measured one, within the range that was stated.
By their numbers in this assay, from the lowest: compounds 2 and 3 (each within the scatter of the next); then compound 4; then compound 1.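

In this assay, within the data shown here, the series shows a number 45 percentage points lower from compound 1 to compound 4 (beyond the scatter) and this is the first single-change step on the aryl ring. With the isopropyl carbamate held constant, a single fluoro ortho to the methylsulfonyl group is enough to lower the maximal response, so this aromatic carbon is not indifferent to the change from hydrogen to fluoro, a point that compounds 2 and 3 could not settle with their different carbamates. No measurement at hand bears on the origin of this fall, and it remains an observation on one pair.

From the compounds shown here alone, it remains open whether the fall is specific to fluoro or would also follow another group on this carbon, such as chloro, methyl or methoxy, and whether a fluoro on the other carbons of this aryl ring would give a step of similar size. Also open is how a ring fluoro acts alongside other carbamates, as no pair among the compounds shown separates the ring fluoro from the carbamate chain in compounds 2 and 3.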